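This account rests on a few compounds, and the source may have more. Where it says the series, first, only, none or still open, it means among the compounds named here.

Working notes on the urea series. The set holds compound 1 `CN(C)CCn1cnnc1-c1cc(Oc2ccc(NC(=O)Nc3cccc(C(F)(F)F)c3)cc2F)ccn1`, compound 2 `CN(C)CCn1cnnc1-c1cc(Oc2ccc(NC(=O)Nc3ccc(Cl)cc3Cl)cc2F)ccn1`, compound 3 `CCN(CC)CCn1cnnc1-c1cc(Oc2ccc(NC(=O)Nc3cccc(C(F)(F)F)c3)cc2F)ccn1` and the unmeasured compound 4 `CCN(CC)CCn1cnnc1-c1cc(Oc2ccc(NC(=O)Nc3ccc(F)c(Cl)c3)cc2F)ccn1`. In an assay on isolated protein for inhibition of proto-oncogene tyrosine-protein kinase receptor Ret (Homo sapiens), read by mobility shift assay, with a stated time of 1 h, tested at 10 uM (on this read-out lower numbers stand for less inhibition and higher numbers for more inhibition at the one concentration tested (going by the name of the read-out)), compound 1 gives 77.7%. Compound 2 carries a 2,4-dichlorophenyl on the urea and in this assay gives "not determined" (no result reported), so no number is available for it. Compound 3 gives 72.1% in this assay.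

For the measured compounds named here, the one fully measured step is the amine swap, a number 5.6 percentage points lower from compound 1 to compound 3 (within the scatter), a change that stays within the scatter. Compound 3 thus stands as the lower of the two numbers available, yet not distinguishable from compound 1.

The step to compound 4 is 3-chloro-4-fluorophenyl in place of 3-(trifluoromethyl)phenyl on an amide-type nitrogen. Going by the values given here, no measured pair in this set varies the aryl on the amide-type nitrogen while holding the rest constant; compound 2, the only other aryl variant, has no result. Among the compounds with values here, the expectation therefore rests only on the size of the single known step and on the fact that the diethylamino side chain of compound 3 is kept. For compound 4 a step of a number 4.1 percentage points lower from compound 3 to compound 4 (within the scatter) in this assay is expected, which would be within the scatter. Compound 4 is estimated at 68% in this assay, with a range from 45% to 85%.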

Compound 4, a percentage reported as inhibition, at one concentration (the size of the read-out at that concentration, not a potency): 1.9%
Beside the measured number, compound 4's estimate is 66.1 percentage points above it; measured number outside the range, below it.
By their numbers in this assay, from the lowest: compound 4; then compounds 3 and 1 (each within the scatter of the next).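

In this assay, for the compounds shown here, the aryl on the amide-type nitrogen is the first place where a single change moves the read-out beyond the scatter: 3-chloro-4-fluorophenyl in place of 3-(trifluoromethyl)phenyl gives a number 70.2 percentage points lower from compound 3 to compound 4 (beyond the scatter), whereas the amine swap on the side chain gave only a number 5.6 percentage points lower from compound 1 to compound 3 (within the scatter). Of the two steps that can be read, the large one therefore lies at this aryl and not at the amine end of the side chain, and with the diethylamino side chain held constant the two aryl groups are clearly not interchangeable. No measurement at hand bears on what lies behind this step, so it stands as an observation without an explanation.

Going by these compounds alone, the single aryl pair does not separate the contribution of the chlorine, the fluorine and the loss of the trifluoromethyl group, which a 3-chlorophenyl or a 4-fluorophenyl group on the same nitrogen could help to resolve. From the compounds shown here alone, it also remains open whether the same aryl change would give a step of similar size with the dimethylamino side chain of compound 1.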